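Working notes: changing the ether group of compound 1

This account rests on a few compounds, and the source may have more. Where it says the series, first, only, none or still open, it means among the compounds named here.

Measured in a functional assay on NCI-N87 cells (Homo sapiens) for inhibition, read by CellTiter-Glo, with a stated time of 72 h; a higher number here means a weaker inhibitor, a lower number a stronger inhibitor:
- compound 1 `Cc1cc(Nc2ncnc3cc(O)c(NC(=O)/C=C/[C@H]4CCCN4C)cc23)ccc1Oc1ccn2ncnc2c1`: 2.65 nM
- compound 2 `C=CC(=O)Nc1cc2c(Nc3ccc(Oc4cc5nncn5cn4)c(C)c3)ncnc2cc1OCC`: 51.9 nM

Compound 1 has the lower of the two numbers, and the gap up to compound 2 lies beyond the usual scatter. The two compounds differ in more than one place, so their gap isolates no single change.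

Compound 3 `Cc1cc(Nc2ncnc3cc(O)c(NC(=O)/C=C/[C@H]4CCCN4C)cc23)ccc1Oc1cnn2cnnc2c1` keeps the rest of compound 1 and changes one group, on an oxygen on an aromatic ring: a group of 9 heavy atoms (5 carbon, 4 nitrogen; one five-membered aromatic ring with 3 hetero atoms, one six-membered aromatic ring with 2 hetero atoms) in place of a group of 9 heavy atoms (6 carbon, 3 nitrogen; one five-membered aromatic ring with 3 hetero atoms, one six-membered aromatic ring with 1 hetero atom), on an oxygen on an aromatic ring. Within the data shown here, no measured pair covers this change. Compound 2, at 51.9 nM, also carries a six-membered aromatic ring with 2 hetero atoms, which gives only weak support for a rise in the number in this assay. A moderate weakening is therefore expected, and the expected size is a 3.0-fold higher number from compound 1 to compound 3 (0.48 log units; beyond the scatter). The estimate for compound 3 is 8 nM, with a range of 2.5 nM to 30 nM.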

Compound 3, half-maximal inhibitory concentration: 28.3 nM
Compound 3: the middle estimate sits 3.5-fold (0.55 log units) below what was measured, and the stated range covers the measured number.
By their numbers in this assay, from the lowest: compound 1; then compounds 3 and 2 (each within the scatter of the next).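

In this assay, the group on the oxygen on an aromatic ring proves sensitive to a small change: with the rest of compound 1 kept and 9 heavy atoms on both sides, the group with 5 carbon and 4 nitrogen gives an 11-fold higher number from compound 1 to compound 3 (1.03 log units; beyond the scatter) and a large loss against the group with 6 carbon and 3 nitrogen. Among these compounds, this is the first step that isolates a single place, which the gap between compound 1 and compound 2 could not do. Nothing measured here explains the size of this step.

Still open, on these data alone, is whether any added ring nitrogen in this group carries the same cost, or only this arrangement of atoms. Also open, as far as these compounds go, is how a plain phenyl ring or a simple pyridine ring on the same oxygen would read.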